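A Fluorine Added to the Fused Ring of Compound 1

The source may hold more compounds than are shown below. What is called first, only, known or untested is meant among the compounds shown, and "the series" means these compounds.

Compound 1 `FC(F)(F)c1ccccc1-c1ccc2[nH]c(C3=NOC4(CCCCC4)C3)nc2c1`: 3.1 nM
Compound 2 `FC(F)Oc1ccccc1-c1ccc2[nH]c(C3=NOC4(CCCCC4)C3)nc2c1`: 2.5 nM
Compound 3 `Fc1cccc(C(F)(F)F)c1-c1ccc2[nH]c(C3=NOC4(CCCCC4)C3)nc2c1`: 0.6 nM

Of the compounds shown here, three sharing one core have been measured in a functional assay on HEK293 cells for antagonist activity at transient receptor potential M8 protein (Canis lupus familiaris), read by FLIPR and calcium flux; on this read-out higher numbers stand for weaker inhibition and lower numbers for stronger inhibition. Compound 1 stands at the highest number of the three. Compound 2 sits close to it, with a 1.2-fold lower number from compound 1 to compound 2 (0.09 log units; within the scatter). Compound 3 is furthest away, with a 5.2-fold lower number from compound 1 to compound 3 (0.71 log units; beyond the scatter).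

Compound 4 `Fc1cc(-c2ccccc2C(F)(F)F)cc2nc(C3=NOC4(CCCCC4)C3)[nH]c12` has not been measured. It differs from compound 1 by fluoro in place of hydrogen on an aromatic carbon. Among the measured steps, only the one from compound 1 to compound 3 also exchanges hydrogen for fluoro, and there the gain was a 5.2-fold lower number from compound 1 to compound 3 (0.71 log units; beyond the scatter); yet in compound 3 the new fluorine does not sit on the fused two-ring system of the shared core, as its structure shows, so that step bears only loosely. The change to compound 2 touches another group altogether and its step, a 1.2-fold lower number from compound 1 to compound 2 (0.09 log units; within the scatter), says little here. Within the data shown here, with no measured step at this place, compound 4 is expected to show a small step or none beyond the scatter, a 1.2-fold lower number from compound 1 to compound 4 (0.09 log units; within the scatter). Compound 4 is therefore estimated at 2.5 nM, with an expected range from 0.8 nM to 8 nM.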

Compound 4, half-maximal inhibitory concentration: 2.2 nM
Estimate against measurement, compound 4: 1.1-fold (0.06 log units) above; the range from low to high includes it.
By their numbers in this assay, from the lowest: compound 3; then compounds 4, 2 and 1 (each within the scatter of the next).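

In this assay, fluoro in place of hydrogen on the six-membered aromatic ring that is part of the fused system gives a 1.4-fold lower number from compound 1 to compound 4 (0.15 log units; within the scatter), so a fluorine at this position can be carried without a shift that stands out from the scatter. The same exchange at another place gave a 5.2-fold lower number from compound 1 to compound 3 (0.71 log units; beyond the scatter), which shows, for these two compounds, that the outcome of adding a fluorine depends on where it sits. Nothing on hand explains why the two places differ.

From the compounds shown here alone, what remains open is whether a different group at this position, such as a methoxy group, a nitrile or an amine, would move the number beyond the scatter. Also open, going by these compounds, is whether a fluorine here would combine with the fluorine of compound 3 to give a further step.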